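Aryl substituent changes on the shared core

The source may report more compounds than this note shows. Statements on the series, on what has been measured and on what is new or still open speak of the compounds shown alone.

Measured so far, in a functional assay on MGC-803 cells (Homo sapiens) for antiproliferative activity, read by MTT assay, with a stated time of 72 h; on this read-out lower numbers stand for stronger inhibition and higher numbers for weaker inhibition:
compound 1 `COc1ccccc1/C=C/C(=O)c1ccc(OCC(=O)N[C@H]2CCOC2=O)cc1`: 39400 nM
compound 2 `CC(C)(C)c1ccc(/C=C/C(=O)c2ccc(OCC(=O)N[C@H]3CCOC3=O)cc2)cc1`: 17200 nM
compound 3 `O=C(COc1ccc(C(=O)/C=C/c2cccc(Br)c2)cc1)N[C@H]1CCOC1=O`: 11900 nM

Compound 3 gives the lowest number of the three. Its gap to compound 1 is beyond the scatter (a 3.3-fold lower number from compound 1 to compound 3 (0.52 log units; beyond the scatter)), while the step of a 1.4-fold lower number from compound 2 to compound 3 (0.16 log units; within the scatter) stays within it, so compound 3 and compound 2 cannot be ranked against each other. The step of a 2.3-fold lower number from compound 1 to compound 2 (0.36 log units; beyond the scatter) is the third comparison in the set, and all three moves change only the aryl group on the double-bonded chain carbon.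

Compound 4 `O=C(COc1ccc(C(=O)/C=C/c2cccc([N+](=O)[O-])c2)cc1)N[C@H]1CCOC1=O` is the next variation on that aryl ring: nitro in place of bromo on an aromatic carbon. Going by the values given here, no measured step replaces bromo by nitro, so no direct precedent exists; the only guidance is that swapping the aryl substituent so far moved the number by modest amounts, and the two meta- or para-substituted analogues, compound 2 and compound 3, sit within the scatter of each other. For compound 4 the step of a 1.0-fold higher number from compound 3 to compound 4 (0.00 log units; within the scatter) is therefore expected to stay within the scatter, with the number judged to lie near that of compound 3. The estimate for compound 4 in this assay is 12000 nM, expected between 5000 nM and 30000 nM.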

Compound 4, half-maximal inhibitory concentration: > 64000 nM
Compound 4: a limit, no number; the forecaster's own chance of this, stated with the estimate: 5%; at least 5.3-fold (0.72 log units) between middle value and limit.
By their numbers in this assay, from the lowest: compounds 3 and 2 (each within the scatter of the next); then compound 1. At a limit, above all of these: compound 4.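

Compound 4 in this assay gives no number, only a limit: the limit of > 64000 nM in this assay, at which 1 of the 4 values shown sits. Among the aryl changes shown, nitro in place of bromo at this place, on an aromatic carbon meta to a large group, is the only one to end at a limit, and it gives the first clear separation among compounds 2, 3 and 4: an at least 5.3-fold higher number from compound 3 to compound 4 (0.73 log units; beyond the scatter) and an at least 3.7-fold higher number from compound 2 to compound 4 (0.57 log units; beyond the scatter) both lie beyond the scatter, whereas the bromo and 4-(tert-butyl) analogues could not be ranked against each other. On these data alone, the third step, an at least 1.6-fold higher number from compound 1 to compound 4 (0.21 log units; that floor lies within the scatter), has a floor within the scatter, so this limit alone does not separate that pair, and the true size of all three steps remains unknown.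

As far as these compounds go, a single bromo-to-nitro pair carries this finding, so it remains open whether the loss is particular to nitro or extends to other replacements of bromo at this place. An amine or a carboxylic acid on the same aromatic carbon, read in this assay, would show whether the series tolerates anything beyond the groups shown here.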